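Pyrrolidinyl amides at the ring nitrogen-adjacent position

The compounds below may be only part of what the source reports. "The series", "measured", "known", "first", "only" and "open" are said of these compounds alone.

Three members of the series have been run so far in a functional assay on HEK293 cells for activation of melanin-concentrating hormone receptor 1 (Rattus norvegicus), read by inositol phosphate accumulation; on this read-out lower numbers stand for an effect already at smaller amounts and higher numbers for an effect only at larger amounts of compound. Compound 1 `CC(C)N(C)c1ccc2cc(NC(=O)CCc3ccc(C(F)(F)F)cc3)ccc2n1` gives 140 nM, compound 2 `CN(c1ccc2cc(NC(=O)CCc3ccc(C(F)(F)F)cc3)ccc2n1)C1CCCCC1` gives 1200 nM and compound 3 `CC1CCN(c2ccc3cc(NC(=O)CCc4ccc(C(F)(F)F)cc4)ccc3n2)C1` gives 400 nM. Compound 2 stands highest of the three: its nearest neighbour is compound 3 and its furthest is compound 1, and both gaps lie beyond the scatter.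

The next compound, compound 4 `CC(C)C(=O)NC1CCN(c2ccc3cc(NC(=O)CCc4ccc(C(F)(F)F)cc4)ccc3n2)C1`, is built from compound 2 by the change (3-((isopropylcarbonyl)amino)pyrrolidin-1-yl in place of cyclohexyl(methyl)amino on an aromatic carbon).

Among the measured compounds shown here, two measured steps bear on this. The step of a 3.0-fold lower number from compound 2 to compound 3 (0.48 log units; beyond the scatter) shows that exchanging the cyclohexyl(methyl)amino group for a pyrrolidinyl ring already brings the number down; the step of an 8.6-fold higher number from compound 1 to compound 2 (0.93 log units; beyond the scatter) shows that the larger cyclohexyl group is the least favourable of the measured variants. For the measured compounds named here, the amide branch on the pyrrolidine ring of compound 4 has no measured counterpart, so its own contribution is unknown.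

On this basis a downward step is expected in this assay, of roughly the size of the measured step just described, with the amide branch left as an open question. For compound 4 the expected step is a 2.7-fold lower number from compound 2 to compound 4 (0.43 log units; beyond the scatter). Compound 4 is estimated at 450 nM, within 130 nM to 2500 nM.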

Compound 4, half-maximal effective concentration: 90 nM
For compound 4 the middle estimate is 5.0-fold (0.70 log units) above the measured one; measured number outside the range, below it.
By their numbers in this assay, from the lowest: compounds 4 and 1 (each within the scatter of the next); then compound 3; then compound 2.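

In this assay, the step of a 4.4-fold lower number from compound 3 to compound 4 (0.65 log units; beyond the scatter) shows that the pyrrolidine ring carbon that holds methyl in compound 3 also accepts (isopropylcarbonyl)amino, and that this exchange lowers the number rather than merely leaving it in place. The full change, a 13-fold lower number from compound 2 to compound 4 (1.12 log units; beyond the scatter), therefore goes well beyond the exchange of cyclohexyl(methyl)amino for the methyl-bearing ring, a 3.0-fold lower number from compound 2 to compound 3 (0.48 log units; beyond the scatter), so the branch contributes to the result alongside the ring itself. At this place next to the ring nitrogen, the step of a 1.6-fold lower number from compound 1 to compound 4 (0.19 log units; within the scatter) leaves the branched pyrrolidine and the isopropyl(methyl)amino group of compound 1 inseparable, and nothing at hand accounts for the branch's contribution.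

Still open, from the compounds shown here alone, is which part of the branch carries the effect: a free amine, an acetyl amide, a longer acyl chain or a carboxylic acid on the same ring carbon would separate the amide link from the isopropyl end. Also open, going by these compounds, is whether the two mirror-image forms at that ring carbon read alike on this scale.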